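The source may hold more compounds than are shown below. What is called first, only, known or untested is meant among the compounds shown, and "the series" means these compounds.

Measured in a physicochemical assay for solubility; a higher number here means a more soluble compound, a lower number a less soluble compound:
- Compound 1 `CNC(=O)c1cc(C(=O)N[C@H]2[C@@H]3C[C@H](O)C[C@@H]32)cc2c1OC[C@@]2(C)c1ccccc1`: >= 151 ug/mL, a limit
- Compound 2 `CNC(=O)c1cc(C(=O)NC2CC2)cc2c1OC[C@@]2(C)c1ccccc1`: >= 138 ug/mL, a limit

Compound 2 has no exact number in this assay. Compound 2 reads >= 138 ug/mL, and this is a limit of the assay. Compound 1 reads >= 151 ug/mL, and this too is a limit.

The next compound to be read is compound 3 `CNC(=O)c1cc(C(=O)NC)c2c(c1)[C@](C)(c1ccccc1)CO2`. The change leading to it is methyl in place of cyclopropyl on an amide-type nitrogen, which in words is methyl in place of cyclopropyl on an amide-type nitrogen.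

Among the measured compounds shown here, only one measured step bears on this, as it also exchanges the group on an amide-type nitrogen: a step that the two limits leave unreadable from compound 1 to compound 2. That step offers no size to carry over and no direction to follow.

With nothing pointing either way, the working expectation is no shift beyond the scatter. The estimated step in this assay is a step that the limit leaves unreadable from compound 2 to compound 3. Compound 3 may well be reported only as a limit too. For compound 3 the expected value is 150 ug/mL, with an estimated range from 75 ug/mL to 250 ug/mL.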

Compound 3, solubility: >= 132 ug/mL
Compound 3: no number, only a limit; the forecaster's own chance of this, stated with the estimate: 65%; the middle value lies beyond the limit too.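

In this assay, among the compounds shown here, compound 1, compound 2 and compound 3 all stand only as limits, and no step among them can be read. The compounds shown leave open whether exchanging the group on the amide-type nitrogen moves this read-out at all, and in which direction, with no exact number for any of the three.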